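A few compounds are considered here, and "the series" means these few. Any claim that something is new, unique, unknown or untested is made for them only; others in the source may bear on it.

Compound 1 `Cn1cc(NC(=O)c2cnc3ccc(N4CCC[C@@H](N)C4)nn23)c(C(F)F)n1`: 41700 nM
Compound 2 `Cn1cc(NC(=O)c2cnc3ccc(N[C@@H]4CCCNC4)nn23)c(C(F)F)n1`: 40100 nM
Compound 3 `Cn1cc(NC(=O)c2cnc3ccc(N[C@@H]4CCNC4)nn23)c(C(F)F)n1`: > 50000 nM

All three were tested in a functional assay on HT cells (Homo sapiens) for cytotoxicity, read by CCK-8 assay, with a stated time of 72 h; on this read-out higher numbers stand for weaker inhibition and lower numbers for stronger inhibition. Compound 3 gives only > 50000 nM, which is a limit of the assay and not a number. It stands at the limit of > 50000 nM in this assay, at which 1 of the 3 values shown sits, so there is no exact value to start from.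

Compound 4 `Cn1cc(NC(=O)c2cnc3ccc(N[C@@H]4CCCCNC4)nn23)c(C(F)F)n1` differs from compound 3 in one place: azepan-3-yl in place of pyrrolidin-3-yl on a nitrogen on an aromatic ring. In words, azepan-3-yl stands in place of pyrrolidin-3-yl on a nitrogen on an aromatic ring.

The closest measured change is the swap of piperidin-3-yl for pyrrolidin-3-yl at that same place, an at least 1.2-fold higher number from compound 2 to compound 3 (0.09 log units; that floor lies within the scatter). The other two changes also stay small: a 1.0-fold lower number from compound 1 to compound 2 (0.02 log units; within the scatter) and an at least 1.1-fold higher number from compound 1 to compound 3 (0.07 log units; that floor lies within the scatter). None of the three goes beyond the scatter, so they point to no direction, and no step beyond the scatter is expected here.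

The expected step is an at least 1.1-fold lower number from compound 3 to compound 4 (0.04 log units; that floor lies within the scatter). For compound 4 the estimated value is 45000 nM, with an expected range from 25000 nM to 70000 nM.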

Compound 4, half-maximal inhibitory concentration: 35900 nM
Beside the measured number, compound 4's estimate is 1.3-fold (0.10 log units) above it; the range from low to high includes it.
By their numbers in this assay, from the lowest: compounds 4, 2 and 1 (each within the scatter of the next). At a limit, above all of these: compound 3.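

In this assay, azepan-3-yl in place of piperidin-3-yl gives a 1.1-fold lower number from compound 2 to compound 4 (0.05 log units; within the scatter), and (azepan-3-yl)amino in place of 3-aminopiperidin-1-yl gives a 1.2-fold lower number from compound 1 to compound 4 (0.07 log units; within the scatter). Compound 3 has only a limit of the assay and not a number: the limit of > 50000 nM in this assay, at which 1 of the 4 values shown sits. Azepan-3-yl in place of pyrrolidin-3-yl gives an at least 1.3-fold lower number from compound 3 to compound 4 (0.14 log units; that floor lies within the scatter), so the seven-membered non-aromatic ring extends the series at this nitrogen without any step beyond the scatter.

The compounds shown therefore leave open whether any change at this position can move the number beyond the scatter. Going by these compounds, what an open-chain amine or a carboxylic acid would do on this nitrogen also remains unknown.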